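The compounds below may be only part of what the source reports. "The series", "measured", "known", "first", "only" and "open" are said of these compounds alone.

Measured compounds:
- compound 1 `O=c1c(-c2ccc(O)cc2)coc2cc(OCCCCCCBr)ccc12`; in a functional assay on mitochondria (Cricetulus griseus) for inhibition of Monoamine oxidase (Homo sapiens), tested at 0.3 uM (a higher number here means a stronger effect of the compound at the concentration tested, a lower number a weaker effect), compound 1 gives 47.2%
- compound 2 `O=c1c(-c2ccc(O)cc2)coc2cc(OCCC3OCCCO3)ccc12`; in this assay compound 2 gives 41%

For the measured compounds named here, on these two numbers compound 2 stands lowest, with compound 1 as its only neighbour; the step of a number 6.2 percentage points lower from compound 1 to compound 2 (within the scatter) lies within the scatter, so the two cannot be ordered. Compound 3 `O=c1c(-c2ccc(O)cc2)coc2cc(OCCCBr)ccc12` is the next compound to be tested. It differs from compound 2 by a group of 2 heavy atoms (1 carbon, 1 bromine; no ring) in place of a group of 6 heavy atoms (4 carbon, 2 oxygen; one six-membered non-aromatic ring with 2 hetero atoms), on a saturated chain carbon, two bonds along the chain from an oxygen on an aromatic ring. Going by the values given here, the one measured step that bears on this place is a number 6.2 percentage points lower from compound 1 to compound 2 (within the scatter), where a bromine-ending chain gave way to the ring-bearing chain at the same position without a change beyond the scatter. Compound 3 returns a bromine-ending chain, now shorter, to that position. Among the compounds with values here, since the only comparable exchange produced nothing beyond the scatter, the step to compound 3 is expected to be a number 3 percentage points higher from compound 2 to compound 3 (within the scatter). Compound 3 is therefore estimated at 44% in this assay, within 25% to 63%.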

Compound 3, a percentage reported as inhibition, at one concentration (the size of the read-out at that concentration, not a potency): 51.1%
For compound 3 the middle estimate is 7.1 percentage points below the measured one, and the stated range covers the measured number.
By their numbers in this assay, from the lowest: compounds 2, 1 and 3 (each within the scatter of the next, the first and the last beyond it).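

Among the compounds shown, the only step at this position that passes the scatter is the exchange of the ring-bearing group for bromomethyl on the saturated chain carbon, which gives a number 10.1 percentage points higher from compound 2 to compound 3 (beyond the scatter) in this assay and is modest in size. Chain length among the bromine-ending compounds does not separate them: bromo in place of 3-bromopropyl gives a number 3.9 percentage points higher from compound 1 to compound 3 (within the scatter) and so leaves the shorter and longer chains unordered. Nothing available explains the step from the ring-bearing chain to the shorter bromine-ending chain.

On these data alone, compound 2 stands apart from compound 3 but not from compound 1, so it remains open whether the ring-bearing group truly lowers the read-out. Also open, as far as these compounds go, is what an amine or a carboxylic acid at the chain end, or a chain longer than that of compound 1, would give.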